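A few compounds are considered here, and "the series" means these few. Any claim that something is new, unique, unknown or untested is made for them only; others in the source may bear on it.

Compounds measured so far:

Compound 1, `COc1cc(-c2cc(/C=C/C(=O)c3ccc(N)cc3)[nH]n2)cc(OC)c1OC`: 2660 nM
Compound 2, `COc1ccc(-c2cc(/C=C/C(=O)c3ccc(N)cc3)[nH]n2)cc1OC`: 3530 nM

Both compounds were tested in a functional assay on SF-539 cells (Homo sapiens) for inhibition, read by sulforhodamine B assay, with a stated time of 48 h; on this read-out lower numbers stand for stronger inhibition of growth and higher numbers for weaker inhibition of growth. Compound 1 gives 2660 nM, the lowest of the two numbers shown, and compound 2 gives 3530 nM; the step of a 1.3-fold higher number from compound 1 to compound 2 (0.12 log units; within the scatter) lies within the scatter, so the two values cannot be told apart.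

Compound 3, `COc1ccc(C(=O)/C=C/c2cc(-c3cc(OC)c(OC)c(OC)c3)n[nH]2)cc1`, has not yet been measured. It differs from compound 1 by methoxy in place of amino on an aromatic carbon. That is, the 4-aminophenyl group of compound 1 becomes a 4-methoxyphenyl group in compound 3, with the rest of the shared core kept.

Within the data shown here, no measured step touches the amino group: the only step available, from compound 1 to compound 2, changes a methoxy group on the other ring, and it stays within the scatter. So the data give no direct guide, and the expectation must rest on the small size of the one change seen. Compound 3 is estimated to give a somewhat higher number than compound 1, by an expected step of a 1.7-fold higher number from compound 1 to compound 3 (0.23 log units; within the scatter), but this might well fall within the scatter. The estimate for compound 3 is 4500 nM, with a range from 1500 nM to 14000 nM.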

Compound 3, concentration for total growth inhibition: 3080 nM
The estimate for compound 3 lay 1.5-fold (0.16 log units) above the measured number; the range from low to high includes it.
By their numbers in this assay, from the lowest: compounds 1, 3 and 2 (each within the scatter of the next).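

Replacing the 4-aminophenyl group of compound 1 with the 4-methoxyphenyl group of compound 3 is the first change shown on this side of the molecule, and in this assay it gives a 1.2-fold higher number from compound 1 to compound 3 (0.06 log units; within the scatter) and so leaves the two compounds indistinguishable. The swap removes the hydrogen-bond donor counted on the amino group and brings one more heavy atom, yet compound 3 stays within the scatter of compound 1, so for this pair a free amino group at this position is not required for a number in this range. Nothing measured here explains why the two groups read alike.

The compounds shown leave open whether a quite different group at this position, such as a carboxylic acid, a dimethylamino group or a plain hydrogen, would also stay within the scatter or would move the number clearly beyond it. They also leave open whether the same swap would read alike when made on compound 2, which carries one methoxy group fewer on the other ring.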